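Unbound fraction when the saturated ring substituent changes

This account rests on a few compounds, and the source may have more. Where it says the series, first, only, none or still open, it means among the compounds named here.

In an ADME assay on a cell-free system (plasma, Mus musculus) for protein binding, using equilibrium dialysis, with a stated time of 5 h, tested at 5 uM (on this read-out lower numbers stand for a smaller free fraction and higher numbers for a larger free fraction), compound 1 (`O=C(CCSc1nc2ccccc2c(=O)[nH]1)N[C@H]1CC[C@H](c2nnc(-c3ccccc3)o2)CC1`) gives 0.017. Compound 2 (`O=C(CCSc1nc2c(c(=O)[nH]1)CCCC2)N[C@H]1CC[C@H](c2nnc(-c3ccccc3)o2)CC1`) gives 0.012 in the same measurement. For the measured compounds named here, these are the only two numbers available, and they lie within the scatter of each other, so neither stands apart. Going by the values given here, the single measured step is a 1.4-fold lower number from compound 1 to compound 2 (0.15 log units; within the scatter). It is within the scatter and concerns the group on the sulfur.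

Compound 3 (`N#Cc1ccc(O[C@H]2CC[C@H](NC(=O)CCSc3nc4ccccc4c(=O)[nH]3)CC2)cc1Cl`) shares the core of compound 1 and carries 3-chloro-4-cyanophenoxy in place of 5-phenyl-1,3,4-oxadiazol-2-yl on a saturated ring carbon. Among the compounds with values here, no measured step touches this place, so the step to compound 2 bears on the change only indirectly, as a sign of how little the number moved at the other end of the molecule. The data give no direction for the new group, and no step beyond the scatter is expected in this assay. The expected step is a 1.2-fold higher number from compound 1 to compound 3 (0.07 log units; within the scatter). For compound 3 the estimated unbound fraction is 0.02, with an expected range of 0.008 to 0.05.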

Compound 3, unbound fraction: 0.002
Beside the measured number, compound 3's estimate is 10-fold (1.00 log units) above it; measured number outside the range, below it.
By their numbers in this assay, from the lowest: compound 3; then compounds 2 and 1 (each within the scatter of the next).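

For the compounds shown here, the position on the saturated ring carbon, three ring bonds from the ring atom that bears a large group, is the first place where a change clears the scatter in this assay: the swap to 3-chloro-4-cyanophenoxy gives an 8.5-fold lower number from compound 1 to compound 3 (0.93 log units; beyond the scatter), whereas the change on the sulfur gave only a 1.4-fold lower number from compound 1 to compound 2 (0.15 log units; within the scatter). The free fraction therefore responds to this substituent, although the step is modest and rests on a single pair. The swap also changes several things at once, replacing two aromatic rings with one and bringing in chlorine and a nitrile, and no data explain the step or assign it to any one of these features.

Open, as far as these compounds go, is which part of 3-chloro-4-cyanophenoxy goes with the lower number, a question that plain phenoxy, 4-cyanophenoxy and 3-chlorophenoxy at the same carbon would address. Also open, from the compounds shown here alone, are whether an amine or a carboxylic acid there would move the number the other way, and whether the step carries over to the core of compound 2.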